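This account rests on a few compounds, and the source may have more. Where it says the series, first, only, none or still open, it means among the compounds named here.

Among the compounds with values here, in an ADME assay for solubility, in simulated intestinal fluid (a lower number here means a less soluble compound, a higher number a more soluble compound), compound 2 `O=C(Cc1ccc2c(c1)B(O)OC2)NS(=O)(=O)C1CCCC1` gives 880 ug/mL, the only true number so far. Compound 1 `CC(C(=O)NS(=O)(=O)C1CC1)c1ccc2c(c1)B(O)OC2`, also with cyclopropyl on a sulfonyl sulfur, gives > 1000 ug/mL, which is a limit of this assay and not a number. Compound 3 `O=C(Cc1ccc2c(c1)B(O)OC2)NS(=O)(=O)C1CC1` has cyclopropyl in place of cyclopentyl on a sulfonyl sulfur. Within the data shown here, no measured pair shows this change alone, so the expectation leans on the limit reading of compound 1, > 1000 ug/mL. The step expected in this assay is small, upward and within the scatter, an estimated 1.1-fold higher number from compound 2 to compound 3 (0.06 log units; within the scatter). Compound 3 is expected at an estimated 1000 ug/mL, with a range of 550 ug/mL to 1600 ug/mL.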

Compound 3, solubility: 700 ug/mL
Compound 3: middle estimate off by 1.4-fold (0.15 log units), on the high side, within the range that was stated.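

In this assay cyclopropyl in place of cyclopentyl on a sulfonyl sulfur now has a measured pair, with a 1.3-fold lower number from compound 2 to compound 3 (0.10 log units; within the scatter) and so no change that can be told from scatter at this place. Hydrogen in place of methyl on a saturated chain carbon bound to an aromatic carbon and a carbonyl carbon gives an at least 1.4-fold lower number from compound 1 to compound 3 (0.15 log units; that floor lies within the scatter) as its first reading. Compound 1 gives > 1000 ug/mL as a limit and not a number, so this step is only a floor: the limit of > 1000 ug/mL in this assay, at which 1 of the 3 values shown sits.
Left open is how an amine or a carboxylic acid on the sulfonyl sulfur would read in this assay and whether hydrogen in place of methyl reads the same with cyclopentyl on the sulfonyl sulfur.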